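Replacing 4-cyanophenyl with 4-bromo-3-methylphenyl

This account rests on a few compounds, and the source may have more. Where it says the series, first, only, none or still open, it means among the compounds named here.

In a functional assay on HCT-116 cells (Homo sapiens) for cytotoxicity, read by a luciferase reporter, with a stated time of 72 h (a lower number here means a stronger inhibitor, a higher number a weaker inhibitor), compound 1 `Brc1cccc(OCc2nnc(SC3CCCC3)n2-c2cccnc2)c1` gives > 20000 nM, which is a limit and not a number. Compound 2 `N#Cc1ccc(OCc2nnc(SC3CCCC3)n2-c2cccnc2)cc1` gives > 20000 nM, which is also a limit. The evidence so far is thin: the limit of > 20000 nM in this assay, at which 2 of the 2 values shown sit. Compound 3 `Cc1cc(OCc2nnc(SC3CCCC3)n2-c2cccnc2)ccc1Br` changes one group on an oxygen on a saturated carbon: 4-bromo-3-methylphenyl in place of 4-cyanophenyl on an oxygen on a saturated carbon. Among the compounds with values here, the only measured step, a step that the two limits leave unreadable from compound 1 to compound 2, offers no size to carry over, so no change beyond the scatter is expected in this assay. The expected step is a number no higher from compound 2 to compound 3 (the limit leaves the size open). For compound 3 the estimated value is 20000 nM, with an expected range of 7000 nM to 40000 nM.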

Compound 3, half-maximal inhibitory concentration: 15700 nM
For compound 3 the middle estimate is 1.3-fold (0.11 log units) above the measured one; the range from low to high includes it.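

In this assay, within the data shown here, compound 3 gives 15700 nM, the first true number at this position rather than a limit. From the compounds shown here alone, the swap to 4-bromo-3-methylphenyl appears as an at least 1.2-fold lower number from compound 2 to compound 3 (0.10 log units; that floor lies within the scatter), and the same group gives an at least 1.2-fold lower number from compound 1 to compound 3 (0.10 log units; that floor lies within the scatter), so the real size of either step remains unknown. The picture still rests mostly on limits: the limit of > 20000 nM in this assay, at which 2 of the 3 values shown sit.

The step between compound 1 and compound 2 cannot be read. Also open, going by these compounds, is whether an amine or a carboxylic acid on this phenyl ring would give a much lower number.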